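The compounds below may be only part of what the source reports. "The series", "measured", "known", "first", "only" and "open" are said of these compounds alone.

In a functional assay on CWR22R cells (Homo sapiens) for antiproliferative activity, read by propidium iodide staining, with a stated time of 96 h (a higher number here means a weaker inhibitor, a lower number a stronger inhibitor), three compounds sharing one core have been measured. Compound 1 `CC(O)(CSc1ccc(S(F)(F)(F)(F)F)cc1)C(=O)Nc1ccc(S(F)(F)(F)(F)F)cc1` gives 24400 nM, compound 2 `CC(O)(CSc1cccc(S(F)(F)(F)(F)F)c1)C(=O)Nc1ccc(S(F)(F)(F)(F)F)cc1` gives 17700 nM, and compound 3 `CC(O)(CSc1ccc(F)cc1)C(=O)Nc1ccc(S(F)(F)(F)(F)F)cc1` gives 13500 nM. All three numbers lie within the usual scatter of one another, so compound 3 stands level with the other two and not clear of them. Compound 4 `CC(O)(CSc1ccc(C(F)(F)F)cn1)C(=O)Nc1ccc(S(F)(F)(F)(F)F)cc1` differs from compound 3 in the group on the sulfur, with 5-(trifluoromethyl)pyridin-2-yl in place of 4-fluorophenyl on a sulfur. For the measured compounds named here, the one measured step that bears on this part of the molecule is a 1.8-fold lower number from compound 1 to compound 3 (0.26 log units; within the scatter), an exchange of a group on the aromatic ring that stayed within the scatter. Going by the values given here, no measured compound has a hetero atom in this aromatic ring, so that part of the change is untested and the uncertainty is wide. Among the compounds with values here, with only that small step as a guide, no shift beyond the scatter is expected, and the expected size is a 1.1-fold higher number from compound 3 to compound 4 (0.05 log units; within the scatter). Compound 4 is estimated at 15000 nM, with an expected range of 6000 nM to 35000 nM.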

Compound 4, half-maximal inhibitory concentration: 20000 nM
For compound 4 the middle estimate is 1.3-fold (0.12 log units) below the measured one; the measured number falls inside the stated range.
By their numbers in this assay, from the lowest: compounds 3, 2, 4 and 1 (each within the scatter of the next).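

In this assay, the step on the sulfur gives a 1.5-fold higher number from compound 3 to compound 4 (0.17 log units; within the scatter), so a six-membered aromatic ring with a hetero atom and a hydrogen-bond acceptor sits at this position without a shift beyond the scatter. The earlier compounds shown here carried only carbon aromatic rings here, so the part of the change left untested before now has one reading, and it leaves compound 4 level with compound 3. Nothing given here offers an explanation of this result.

The ring nitrogen and the trifluoromethyl group enter together, so the compounds shown do not separate their contributions. Going by these compounds, it also stays open whether anything at this position moves the number beyond the scatter, for instance an amine or a carboxylic acid on the ring, or a simple alkyl chain on the sulfur in place of the ring.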